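The source may hold more compounds than are shown below. What is called first, only, known or untested is meant among the compounds shown, and "the series" means these compounds.

Of the compounds shown here, two built on a shared core have been measured in a physicochemical assay for lipophilicity, at pH 7.4; a higher number here means a more lipophilic compound, a lower number a more polar compound. Compound 1, `Cc1ccccc1-c1ccc(-c2nnc(N(C)Cc3ccc4nccn4c3)o2)cc1`, gives 4.7 in this assay. Compound 2, `Cc1nn(C)c(C)c1-c1ccc(-c2nnc(N(C)Cc3ccc4nccn4c3)o2)c(F)c1`, gives 3.2 in this assay. Of these two numbers, the value of compound 2 is the lowest; its nearest neighbour is compound 1, whose number stands higher by a gap beyond the usual scatter of such measurements.

Compound 3, `COc1cc(-c2c(C)nn(C)c2C)ccc1-c1nnc(N(C)Cc2ccc3nccn3c2)o1`, has not yet been measured. It differs from compound 2 in one place: methoxy in place of fluoro on an aromatic carbon, in words a methoxy in place of fluoro on an aromatic carbon. Within the data shown here, no pair of measured compounds shows this exchange, so there is no measured step to lean on, and the expectation rests on the value of compound 2 alone together with the small size of the change counted above. Among the measured compounds shown here, nothing among the measured compounds points in either direction for this exchange, so the step of a number 0.10 log units lower from compound 2 to compound 3 (within the scatter) is expected to be none beyond the scatter. Compound 3 is therefore estimated at 3.1, with a range from 2.6 to 3.6.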

Compound 3, distribution coefficient: 2.9
Compound 3: the middle estimate sits 0.20 log units above what was measured; the measured number falls inside the stated range.
By their numbers in this assay, from the lowest: compounds 3 and 2 (each within the scatter of the next); then compound 1.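

Among these compounds, this is the first measured exchange at this position, an aromatic carbon ortho to a large group and meta to a 1,3,5-trimethyl-1H-pyrazol-4-yl group. In this assay, putting methoxy in place of fluoro gives a step of a number 0.30 log units lower from compound 2 to compound 3 (within the scatter), so the two compounds cannot be told apart in this assay. The change is not empty on paper, since methoxy has more heavy atoms than fluoro and brings a hydrogen-bond acceptor, yet on this core and at this position those differences come with no reading beyond the scatter, and no measurement at hand offers an explanation for the size of this step.

A single exchange says little about the position as a whole, and an amine, a carboxylic acid, a hydroxyl group or a longer ether chain at the same carbon could give quite a different reading. Going by these compounds, it also remains open whether methoxy in place of fluoro would give a similarly small step on another aromatic carbon or with a different group in place of the 1,3,5-trimethyl-1H-pyrazol-4-yl group.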